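A few compounds are considered here, and "the series" means these few. Any claim that something is new, unique, unknown or untested is made for them only; others in the source may bear on it.

Going by the values given here, the three compounds measured so far share one core, an oleoyl-type ketone joined to a fused bicyclic heteroaryl, and differ only in that bicycle. In an assay on isolated protein for inhibition of Fatty-acid amide hydrolase 1 (Homo sapiens) (on this read-out higher numbers stand for weaker inhibition and lower numbers for stronger inhibition), compound 1 `CCCCCCCC/C=C\CCCCCCC(=O)c1nc2cccnc2o1` gives 11 nM. Compound 2 `CCCCCCCC/C=C\CCCCCCC(=O)c1nc2cccc(C)c2o1` gives 13000 nM in this assay. Compound 3 `CCCCCCCC/C=C\CCCCCCC(=O)c1nc2c(C)cccc2o1` is reported in this assay only as a limit, > 100000 nM, so no number is known for it; it sits at the limit described by the limit of > 100000 nM in this assay, at which 1 of the 3 values shown sits, and stands at the weak end of the three values shown. Compound 4 `CCCCCCCC/C=C\CCCCCCC(=O)c1nc2ccccc2o1` has not yet been measured in this assay. Compared with compound 3 it differs by hydrogen in place of methyl on an aromatic carbon: the methyl of compound 3 is gone and the fused carbocyclic ring carries only hydrogens. Since compound 2 and compound 3, which each carry a methyl, are both far weaker than compound 1, removing the methyl is expected to move the value well beyond the scatter toward stronger inhibition, though compound 1 also differs from compound 4 in its ring. Compound 4 is therefore expected to give about 400 nM in this assay, within a range of 50 nM to 3000 nM, an estimated step of an at least 250-fold lower number from compound 3 to compound 4 (2.39 log units; beyond the scatter).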

Compound 4, inhibition constant: 370 nM
For compound 4 the middle estimate is 1.1-fold (0.03 log units) above the measured one; low and high end bracket the measured number.
By their numbers in this assay, from the lowest: compound 1; then compound 4; then compound 2. At a limit, above all of these: compound 3.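

Going by these compounds alone, compound 4 supplies the reference that the earlier compounds lacked: in this assay, replacing the methyl of compound 2 with hydrogen gives a 35-fold lower number from compound 2 to compound 4 (1.55 log units; beyond the scatter), so a methyl on the fused carbocyclic ring is now seen to weaken inhibition on its own, with the ring otherwise unchanged. Compound 3 is known only as a limit, so its step, an at least 270-fold lower number from compound 3 to compound 4 (2.43 log units; beyond the scatter), is a bound and not a measured size, though it points the same way for the second methyl placement: the limit of > 100000 nM in this assay, at which 1 of the 4 values shown sits. The same reference also separates the ring from the methyl, since a 34-fold higher number from compound 1 to compound 4 (1.53 log units; beyond the scatter) shows that the six-membered aromatic ring with a hetero atom in compound 1 outperforms the all-carbon ring of compound 4 even with no methyl present, and so the methyl accounts for only part of the distance between compound 1 and the methyl compounds.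

From the compounds shown here alone, whether a group other than methyl, such as fluorine or methoxy, would weaken inhibition in the same way on this ring remains open. Also open, going by these compounds, are whether a methyl would have a similar effect on the ring of compound 1, and how a shorter chain in place of the oleoyl-type chain would change these steps.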